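A few compounds are considered here, and "the series" means these few. Any claim that something is new, unique, unknown or untested is made for them only; others in the source may bear on it.

In an ADME assay on the whole organism (strain CD-1) for pharmacokinetics, with Mus musculus as the target, at a dose of 3 mg/kg by the intravenous route (on this read-out higher numbers stand for fast clearance and lower numbers for slow clearance), compound 3 (`CN(Cc1ccccc1OCCC/C=C/C(=O)O)C(=O)c1ccc(-c2ccco2)cc1`) stands highest at 67 mL/min/kg against compound 1 (`CC(CCCCOc1ccccc1CN(C)C(=O)c1ccc(-c2ccco2)cc1)C(=O)O`) at 3 mL/min/kg and compound 2 (`C[C@H](CCCOc1ccccc1CN(C)C(=O)c1ccc(-c2ccco2)cc1)CC(=O)O`) at 0.3 mL/min/kg in this small set. Compound 4 (`C/C(=C\CCCOc1ccccc1CN(C)C(=O)c1ccc(-c2ccco2)cc1)C(=O)O`) differs from compound 3 by 2-carboxyprop-1-en-1-yl in place of 2-carboxyethenyl on a saturated chain carbon, three bonds along the chain from an oxygen on an aromatic ring at the same place, with 2-carboxyprop-1-en-1-yl in place of 2-carboxyethenyl. Going by the values given here, no measured step isolates this change. The nearest evidence is the large step of a 22-fold higher number from compound 1 to compound 3 (1.35 log units; beyond the scatter) (with the methyl branch of compound 1 kept in compound 4 alongside the double bond of compound 3). The steps of a 10-fold lower number from compound 1 to compound 2 (1.00 log units; beyond the scatter) and a 220-fold higher number from compound 2 to compound 3 (2.35 log units; beyond the scatter) involve a differently placed branch and bear less directly. A modest fall in this assay is therefore expected, an estimated 3.4-fold lower number from compound 3 to compound 4 (0.53 log units; beyond the scatter) overall. Compound 4 is estimated at 20 mL/min/kg with 5 mL/min/kg to 60 mL/min/kg as the expected range.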

Compound 4, clearance: 4 mL/min/kg
Compound 4: the middle estimate sits 5.0-fold (0.70 log units) above what was measured; measured number below the stated range.
By their numbers in this assay, from the lowest: compound 2; then compounds 1 and 4 (each within the scatter of the next); then compound 3.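

Replacing 2-carboxyethenyl with 2-carboxyprop-1-en-1-yl at this position gives a 17-fold lower number from compound 3 to compound 4 (1.22 log units; beyond the scatter) in this assay and shows that the double bond alone does not set a high clearance here. The unsaturated chain of compound 4 stands level with the saturated chain of compound 1 in a 1.3-fold higher number from compound 1 to compound 4 (0.12 log units; within the scatter) while a 13-fold higher number from compound 2 to compound 4 (1.12 log units; beyond the scatter) still sets compound 2 apart. Nothing available explains these differences.

Open, on these data alone, is whether an ethyl branch in place of the methyl would give the same clearance. A tetrazole in place of the carboxylic acid is also untested among these compounds.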